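A few compounds are considered here, and "the series" means these few. Any claim that something is new, unique, unknown or untested is made for them only; others in the source may bear on it.

Working notes on the thiazolo-fused series, first pass.

Compound 1 `CCOC(=O)c1csc2nc(CN3CCN(Cc4ccccc4)CC3)c(-c3ccc(C)cc3)n12` carries a 4-methylphenyl group and a benzylpiperazine side chain on the ester-bearing core. In a functional assay on PC-3 cells (Homo sapiens) for antiproliferative activity, read by MTT assay, with a stated time of 72 h (on this read-out lower numbers stand for stronger inhibition and higher numbers for weaker inhibition), compound 1 gives > 100000 nM, which is a limit of the assay rather than a number. Compound 2 `CCOC(=O)c1csc2nc(CN3CCN(Cc4ccccc4)CC3)c(-c3ccc(OC)cc3)n12` differs from compound 1 only by methoxy in place of methyl on an aromatic carbon and in this assay compound 2 gives 29400 nM. The step of an at least 3.4-fold lower number from compound 1 to compound 2 (0.53 log units; beyond the scatter) is given only as a minimum because the limit of > 100000 nM in this assay, at which 1 of the 3 values shown sits, caps what compound 1 could show.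

Compound 3 `Cc1ccc(-c2c(CN3CCCCC3)nc3scc(C(=O)O)n23)cc1` sits on a different core, with a piperidine side chain and a free carboxylic acid in place of the ester; how its core differs from that of compound 1 is not broken down here. In this assay compound 3 gives 16600 nM, which lies within the scatter of the number for compound 2, so no order between the two is claimed.

Compound 4 `COc1ccc(-c2c(CN3CCCCC3)nc3scc(C(=O)O)n23)cc1` is not yet measured. It differs from compound 3 by methoxy in place of methyl on an aromatic carbon, the same change that separates compound 1 from compound 2. Given the size of an at least 3.4-fold lower number from compound 1 to compound 2 (0.53 log units; beyond the scatter), a move in the same direction is expected for compound 4, though on a different core and with only one precedent, and the expected step is a 2.1-fold lower number from compound 3 to compound 4 (0.32 log units; beyond the scatter). Compound 4 is therefore estimated at 8000 nM in this assay, with a likely range from 3000 nM to 25000 nM.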

Compound 4, half-maximal inhibitory concentration: 73100 nM
For compound 4 the middle estimate is 9.1-fold (0.96 log units) below the measured one; measured number above the stated range.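

In this assay the change from 4-methylphenyl to 4-methoxyphenyl gives a 4.4-fold higher number from compound 3 to compound 4 (0.64 log units; beyond the scatter), so on this core the number rises rather than falls. The change therefore does not keep its direction from one core to the other, and the earlier step cannot serve as a guide to the later one: the same change on two cores in this assay, an at least 3.4-fold lower number (0.53 log units; beyond the scatter) from compound 1 to compound 2 and a 4.4-fold higher number (0.64 log units; beyond the scatter) from compound 3 to compound 4, at least 14-fold (1.17 log units) apart, beyond the scatter of two such steps
This rests on only two pairs, which differ from each other at once in the core, in the side chain, and in ethyl ester against free carboxylic acid; it does not show which of these goes with the reversal, and the earlier step remains a minimum, its size capped by a limit of the assay and not set by a number: the limit of > 100000 nM in this assay, at which 1 of the 4 values shown sits.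

The compounds shown leave open whether the direction of the step follows the side chain or the carboxylic acid, a question that a benzylpiperazine side chain on the acid, or a piperidine side chain on the ethyl ester, would bear on. Also open, from the compounds shown here alone, is how other groups on the same aromatic carbon, such as chlorine or hydroxyl, would read on each core.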